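A few compounds are considered here, and "the series" means these few. Any claim that something is new, unique, unknown or untested is made for them only; others in the source may bear on it.

Measured so far in a physicochemical assay for acid dissociation:
compound 1 `CC(C)Cc1ccc2c(NCCCNCc3ccco3)ccnc2c1` gives 9.47
compound 2 `c1ccc(-c2ccc3c(NCCCNCc4ccco4)ccnc3c2)cc1` gives 9.47
compound 3 `Cc1cc(C)cc(Cc2ccc3c(NCCCNCc4ccco4)ccnc3c2)c1` gives 9.47

All three stand level at the digits printed: no change at the digits printed from compound 1 to compound 2 (within the scatter), no change at the digits printed from compound 2 to compound 3 (within the scatter), and no change at the digits printed from compound 1 to compound 3 (within the scatter). All three steps concern the group on an aromatic carbon of the shared core, or on a saturated chain carbon bound to an aromatic carbon, and none of them moved this assay beyond the scatter.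

Compound 4 `COc1cccc(CNCCCNc2ccnc3cc(-c4ccccc4)ccc23)c1O` differs from compound 2 elsewhere: 2-hydroxy-3-methoxyphenyl in place of furan-2-yl on a saturated chain carbon bound to an amine nitrogen. Among the compounds with values here, no measured step touches a saturated chain carbon bound to an amine nitrogen, so the measured steps do not bear directly on this change; they show only that three changes at other places left this assay unchanged. With no comparison available for this position, the expectation is a step close to the scatter, a number 0.17 log units lower from compound 2 to compound 4 (within the scatter), with a wider range than for the measured steps. Compound 4 is estimated at 9.3, expected between 8.7 and 9.9.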

Compound 4, acid dissociation constant: 9.47
Beside the measured number, compound 4's estimate is 0.17 log units below it, and the stated range covers the measured number.
By their numbers in this assay, from the lowest: compounds 1, 2, 3 and 4 (each within the scatter of the next).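

Placed in this assay, 2-hydroxy-3-methoxyphenyl in place of furan-2-yl on a saturated chain carbon bound to an amine nitrogen gives no change at the digits printed from compound 2 to compound 4 (within the scatter), the first reading at this position. The entering group has 9 heavy atoms against 5 and 1 hydrogen-bond donor against 0, yet neither difference appears in the read-out at the digits printed, so this position now stands with the two places already read as a change that leaves this assay level. Nothing on hand offers an explanation for this result.

Still open, going by these compounds, is whether a carboxylic acid or an amine on this same chain carbon would move this assay beyond the scatter. A longer chain linking the two nitrogens of the series is equally unresolved.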